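Swapping trifluoromethyl for chloro on compound 1

This account rests on a few compounds, and the source may have more. Where it says the series, first, only, none or still open, it means among the compounds named here.

- compound 1 `O=C(Nc1cccc(-c2ccccc2C(F)(F)F)c1)C(Cl)Cl`: 7500 nM
- compound 2 `O=C(Nc1cccc(-c2cccs2)c1)C(Cl)Cl`: 47600 nM
- compound 3 `O=C(Nc1cc(-c2ccc(OC3CCCCO3)cc2)cc(-c2ccc(OC3CCCCO3)cc2)c1)C(Cl)Cl`: 2750 nM

All three values come from a functional assay on A549 cells (Homo sapiens) for cytotoxicity, read by MTT assay, with a stated time of 68 h; on this read-out higher numbers stand for weaker inhibition and lower numbers for stronger inhibition. Among them, compound 1 holds the second highest number, 7500 nM. Its nearest neighbour is compound 3 at 2750 nM, lower by more than the usual scatter. The furthest is compound 2 at 47600 nM, higher by more than the scatter.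

Compound 4 `O=C(Nc1cccc(-c2ccccc2Cl)c1)C(Cl)Cl` has not yet been measured in this assay. It keeps the core of compound 1 and changes one group: chloro in place of trifluoromethyl on an aromatic carbon. Among the compounds with values here, no measured pair here shows this swap, and the three measured compounds differ from one another in more than one place, so their spread gives no direct guide to its size. Within the data shown here, with only one group changing, no step beyond the scatter is expected, and neither direction is favoured. Compound 1 at 7500 nM therefore serves as the anchor. The expected step of a 1.2-fold higher number from compound 1 to compound 4 (0.08 log units; within the scatter) is estimated to stay within the scatter. For compound 4 the estimated value is 9000 nM, with an expected range from 3500 nM to 25000 nM.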

Compound 4, half-maximal inhibitory concentration: 22600 nM
The estimate for compound 4 lay 2.5-fold (0.40 log units) below the measured number, within the range that was stated.
By their numbers in this assay, from the lowest: compound 3; then compound 1; then compound 4; then compound 2.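

In this assay, within the data shown here, putting chloro in place of trifluoromethyl gives a 3.0-fold higher number from compound 1 to compound 4 (0.48 log units; beyond the scatter), the first comparison in this set in which only one place changes. The step is modest but beyond the scatter, so the group on this aromatic carbon, ortho to a large group, does affect the read-out, and here the change goes towards weaker inhibition. The swap replaces 4 heavy atoms with 1, and neither group has a ring, a hydrogen-bond donor or acceptor, or a net charge, but no measurement here accounts for why the number rises.

A single pair cannot show whether the number follows the count of heavy atoms in this group or depends on something else about it; a methyl, a methoxy or an amine at the same place would give further points for comparison. As far as these compounds go, it also remains open whether the same swap would produce a similar step on a different core, or on a compound carrying other groups around the ring.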